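The source may hold more compounds than are shown below. What is called first, only, known or untested is meant among the compounds shown, and "the series" means these compounds.

Working notes on the series.

Compound 1 `CO[C@]1(C(=O)N2CC[C@](c3ccc(C(F)(C(F)(F)F)C(F)(F)F)cc3)(S(=O)(=O)c3ccc(F)cc3)C2)CC[C@H](C(=O)O)CC1` stands second highest of the three compounds measured in an ADME assay on microsomes from liver (Homo sapiens) for metabolic stability, with a stated time of 10 min (a higher number here means that more of the compound is left, a lower number that less of the compound is left), where compound 1 gives 82%. Compound 2 `NC(=O)[C@H]1CC[C@H](C(=O)N2CC[C@](c3ccc(C(F)(C(F)(F)F)C(F)(F)F)cc3)(S(=O)(=O)c3ccc(F)cc3)C2)CC1` is the nearest neighbour and gives 100%; the step of a number 18 percentage points higher from compound 1 to compound 2 (beyond the scatter). Compound 3 `CCC1(C(=O)N2CC[C@](c3ccc(C(F)(C(F)(F)F)C(F)(F)F)cc3)(S(=O)(=O)c3ccc(F)cc3)C2)CCS(=O)(=O)CC1` is the furthest and gives 3%; the step of a number 79 percentage points lower from compound 1 to compound 3 (beyond the scatter), and the step of a number 97 percentage points lower from compound 2 to compound 3 (beyond the scatter).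

Compound 4 `O=C(N1CC[C@](c2ccc(C(F)(C(F)(F)F)C(F)(F)F)cc2)(S(=O)(=O)c2ccc(F)cc2)C1)C1(O)CCS(=O)(=O)CC1` is not yet measured. Its change from compound 1: 4-hydroxy-1,1-dioxothian-4-yl in place of 4-carboxy-1-methoxycyclohexyl on a carbonyl carbon. Among the compounds with values here, the one measured step that bears on it is the step from compound 1 to compound 3, which also brings in a 1,1-dioxothian-4-yl ring on the carbonyl carbon and was large and downward. The step from compound 2 to compound 3 points the same way and was larger still. Within the data shown here, no measured pair covers the exchange of ethyl for hydroxy on that ring, so the size is uncertain, but a step beyond the scatter and downward is expected in this assay for compound 4, estimated as a number 47 percentage points lower from compound 1 to compound 4 (beyond the scatter).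

Compound 4 is therefore expected to give 35% in this assay, with an estimated range from 8% to 75%.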

Compound 4, percent of the compound remaining: 100%
Beside the measured number, compound 4's estimate is 65 percentage points below it; measured number above the stated range.
By their numbers in this assay, from the lowest: compound 3; then compound 1; then compounds 2 and 4 (each within the scatter of the next).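

In this assay, hydroxy in place of ethyl on a saturated ring carbon gives a number 97 percentage points higher from compound 3 to compound 4 (beyond the scatter), so the 1,1-dioxothian-4-yl ring on the carbonyl carbon does not by itself go with the low number of compound 3, and between these two compounds the group on that ring carbon decides the reading. Within the data shown here, the 4-hydroxy-1,1-dioxothian-4-yl group compares with 4-carboxy-1-methoxycyclohexyl as a number 18 percentage points higher from compound 1 to compound 4 (beyond the scatter) and with 4-carbamoylcyclohexyl as no change at the digits printed from compound 2 to compound 4 (within the scatter), which leaves compound 3 as the only one of the four compounds with a low number at this position. Nothing measured here gives a reason for the gap between the ethyl and hydroxy compounds.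

Open, going by these compounds, is whether a methyl, a methoxy or an amine on that same ring carbon would read like the hydroxy of compound 4 or like the ethyl of compound 3. Also open, on these data alone, is whether hydroxy gives a similar number on a six-membered ring of carbon only, as in a 4-hydroxycyclohexyl group on the carbonyl carbon.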